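The source may report more compounds than this note shows. Statements on the series, on what has been measured and on what is new or still open speak of the compounds shown alone.

Measured in a functional assay on NCI-H1299 cells (Homo sapiens) for antiproliferative activity, read by fluorescence and resazurin assay, with a stated time of 48 h; on this read-out higher numbers stand for weaker inhibition and lower numbers for stronger inhibition:
compound 1 `Oc1ccc(-c2cn(Cc3ccccc3)cc2-c2ccc(O)cc2)cc1`: 26900 nM
compound 2 `COc1ccc(Cn2cc(-c3ccc(O)cc3)c(-c3ccc(O)cc3)c2)cc1OC`: 29200 nM

Compound 2 at 29200 nM stands level with compound 1, since the two numbers lie within the scatter of each other. Compound 3 `COc1ccc(Cn2cc(-c3ccc(O)cc3)c(-c3ccc(O)cc3)c2)c(OC)c1` has not yet been measured. It differs from compound 2 by 2,4-dimethoxyphenyl in place of 3,4-dimethoxyphenyl on a saturated chain carbon bound to an aromatic nitrogen and thus carries 2,4-dimethoxyphenyl in place of 3,4-dimethoxyphenyl on a saturated chain carbon bound to an aromatic nitrogen. Among the measured compounds shown here, one measured step bears on this place: a 1.1-fold higher number from compound 1 to compound 2 (0.04 log units; within the scatter) came with 3,4-dimethoxyphenyl replacing phenyl and stayed within the scatter. For the measured compounds named here, no measured pair compares the two dimethoxyphenyl groups directly. The expected step is therefore a 1.0-fold lower number from compound 2 to compound 3 (0.00 log units; within the scatter) in this assay and no shift beyond the scatter is expected in either direction. For compound 3 the estimated value is 29000 nM with an expected range from 14000 nM to 58000 nM in this read-out.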

Compound 3, half-maximal inhibitory concentration: 31600 nM
Compound 3: the middle estimate sits 1.1-fold (0.04 log units) below what was measured, and the stated range covers the measured number.
By their numbers in this assay, from the lowest: compounds 1, 2 and 3 (each within the scatter of the next).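

In this assay, among the compounds shown here, 2,4-dimethoxyphenyl in place of 3,4-dimethoxyphenyl on a saturated chain carbon bound to an aromatic nitrogen gives a 1.1-fold higher number from compound 2 to compound 3 (0.03 log units; within the scatter), the first direct comparison of these two dimethoxyphenyl groups. Set against the plain phenyl group, 2,4-dimethoxyphenyl gives a 1.2-fold higher number from compound 1 to compound 3 (0.07 log units; within the scatter), so the second dimethoxyphenyl group also stays within the scatter. At this place, compound 1, compound 2 and compound 3 therefore stand level, whichever of the three groups is present.

As far as these compounds go, whether an amine, a carboxylic acid or a longer chain at this place would depart from that level remains open. Nothing available here bears on why these three groups give numbers within the scatter of one another.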